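The source may report more compounds than this note shows. Statements on the series, on what has been measured and on what is new or still open speak of the compounds shown alone.

Compound 2 `COc1cc(-c2nc3cc(/C=C4\SC(=O)N(CC(=O)N5CCCC5)C4=O)ccc3[nH]2)cc(OC)c1OC` belongs to a small set of two compounds sharing one core. In a functional assay on PC-3 cells (Homo sapiens) for inhibition, read by MTT assay, with a stated time of 48 h (on this read-out lower numbers stand for stronger inhibition and higher numbers for weaker inhibition), compound 2 gives 8370 nM. Going by the values given here, its only neighbour, compound 1 `COc1cc(-c2nc3cc(/C=C4\SC(=O)N(CC(=O)N5CCOCC5)C4=O)ccc3[nH]2)cc(OC)c1OC`, gives 5940 nM. Among the compounds with values here, the single measured step, a 1.4-fold higher number from compound 1 to compound 2 (0.15 log units; within the scatter), stays within the scatter, so the two numbers cannot be told apart; compound 2 simply has the higher of the two figures.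

Compound 3 `COc1cc(-c2nc3cc(/C=C4\SC(=O)N(Cc5cccc(C)c5)C4=O)ccc3[nH]2)cc(OC)c1OC` has not been measured. It differs from compound 2 by 3-methylphenyl in place of (pyrrolidin-1-yl)carbonyl on a saturated chain carbon bound to an amide-type nitrogen in a ring. Within the data shown here, no measured step covers a change of this kind: the only step recorded swaps one small ring for another on the carbonyl carbon and changed nothing beyond the scatter. With no guide from the measured compounds, the expectation for compound 3 in this assay is a number near that of compound 2, with a broad range either way: compound 3 is estimated at 6000 nM, between 1500 nM and 25000 nM. The expected step is a 1.4-fold lower number from compound 2 to compound 3 (0.14 log units; within the scatter).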

Compound 3, half-maximal inhibitory concentration: 4370 nM
The estimate for compound 3 lay 1.4-fold (0.14 log units) above the measured number, and the stated range covers the measured number.
By their numbers in this assay, from the lowest: compounds 3, 1 and 2 (each within the scatter of the next).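

In this assay, the step of a 1.9-fold lower number from compound 2 to compound 3 (0.28 log units; within the scatter) and the step of a 1.4-fold lower number from compound 1 to compound 3 (0.13 log units; within the scatter) show that a much larger change at this place still stays within the scatter. The earlier step only swapped one ring for another on the carbonyl carbon, whereas here the carbonyl and the ring amide both leave, and 3-methylphenyl enters, with 7 heavy atoms, all carbon, and 0 hydrogen-bond acceptors. Across these three compounds, then, the numbers do not separate, whether the group on the saturated chain carbon is a ring amide or an aromatic ring, and no supporting data are available to explain this.

Going by these compounds, whether an amine, a carboxylic acid or a longer chain at this place would give a number beyond the scatter remains open. So does the part played by the methyl group, since plain benzyl does not appear among these compounds.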